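This account rests on a few compounds, and the source may have more. Where it says the series, first, only, none or still open, it means among the compounds named here.

Of the compounds shown here, two have so far been measured in a functional assay on MCF7 cells (Homo sapiens) for antiproliferative activity, read by MTT assay, with a stated time of 72 h; on this read-out higher numbers stand for weaker inhibition and lower numbers for stronger inhibition. Compound 1 `CN1CCN(C(=S)SCc2coc3ccccc3c2=O)CC1` gives 22900 nM. Compound 2 `Cc1ccc2c(=O)c(CSC(=S)N(C(C)C)C(C)C)coc2c1` gives 6600 nM, which is the lowest of the two numbers; the gap between compound 2 and compound 1 lies beyond the usual scatter. Compound 3 `CC(C)N(C(=S)SCc1coc2ccccc2c1=O)C(C)C` has not yet been measured. It differs from compound 2 in one place only: hydrogen in place of methyl on an aromatic carbon. For the measured compounds named here, no pair of measured compounds shows this same change, so there is no measured step to rest on. As the group that leaves is only a methyl, one would expect a small step, and if any, toward a higher number than compound 2 shows. The step from compound 2 to compound 3 is expected to be a 1.4-fold higher number from compound 2 to compound 3 (0.16 log units; within the scatter). Compound 3 is estimated at 9500 nM, with a range from 3500 nM to 26000 nM.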

Compound 3, half-maximal inhibitory concentration: > 30000 nM
Compound 3 ended at the assay's limit; the forecaster's own chance of this, stated with the estimate: 5%; at least 3.1-fold (0.49 log units) between middle value and limit.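

In this assay compound 3 stands only as a limit of the assay, not as a number: the limit of > 30000 nM in this assay, at which 1 of the 3 values shown sits. Even so, the methyl on this aromatic carbon proves to matter: hydrogen in its place gives an at least 4.5-fold higher number from compound 2 to compound 3 (0.65 log units; beyond the scatter), so losing this single carbon is enough to move the read-out past the scatter. On the thiocarbonyl carbon, with hydrogen on the aromatic carbon in both compounds, diisopropylamino in place of 4-methylpiperazin-1-yl gives an at least 1.3-fold higher number from compound 1 to compound 3 (0.11 log units; that floor lies within the scatter), so this change shows no firm direction.

Going by these compounds, whether an ethyl group, a methoxy group or a chlorine atom on the same aromatic carbon would keep the effect of the methyl remains open. So does whether the methyl would have a like effect with 4-methylpiperazin-1-yl on the thiocarbonyl carbon.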